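Trifluoromethylphenyl carbonyl in place of dichlorophenyl carbamoyl

The compounds below may be only part of what the source reports. "The series", "measured", "known", "first", "only" and "open" are said of these compounds alone.

Compound 1 `O=C(Nc1cccc(-n2cc(-c3ccncc3)c(-c3cc(O)cc(Cl)c3)n2)c1)Nc1ccc(Cl)c(C(F)(F)F)c1`: 101%
Compound 2 `O=C(Nc1cccc(-n2cc(-c3ccncc3)c(-c3cc(O)cc(Cl)c3)n2)c1)Nc1ccc(Cl)c(Cl)c1`: 96%
Compound 3 `COc1cc(Cl)cc(-c2nn(-c3cccc(NC(=O)Nc4ccc(Cl)c(Cl)c4)c3)cc2-c2ccncc2)c1`: 99%

In a functional assay on A549 cells (Homo sapiens) for inhibition, read by sulforhodamine B assay, with a stated time of 48 h, tested at 0.01 uM (on this read-out higher numbers stand for a weaker effect at the one concentration tested and lower numbers for a stronger effect), compound 3 gives 99%, which is the second highest of the three numbers; its nearest neighbour is compound 1 at 101%, and compound 2 at 96% lies furthest, with both gaps inside the scatter. The two measured steps were small: a number 5 percentage points lower from compound 1 to compound 2 (within the scatter) and a number 3 percentage points higher from compound 2 to compound 3 (within the scatter). Compound 4 `COc1cc(Cl)cc(-c2nn(-c3cccc(NC(=O)c4cccc(C(F)(F)F)c4)c3)cc2-c2ccncc2)c1` differs from compound 3 in one place: 3-(trifluoromethyl)phenyl in place of (3,4-dichlorophenyl)amino on a carbonyl carbon. Neither measured step touches the carbonyl carbon or the amide-type nitrogen next to it, so nothing directly bears on this change; the only related observation is that a trifluoromethyl and a chloro on the outer ring gave the same result, as a number 5 percentage points lower from compound 1 to compound 2 (within the scatter) shows. All three measured values sit near full activity in this assay, so compound 4 is expected to show no step beyond the scatter, a number 1 percentage points lower from compound 3 to compound 4 (within the scatter). For compound 4 the estimate in this assay is 98%, with a range from 86% to 110%.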

Compound 4, a percentage reported as activity, at one concentration (the size of the read-out at that concentration, not a potency): 98%
Compound 4: the middle estimate sits on the measured number at the digits printed, within the range that was stated.
By their numbers in this assay, from the lowest: compounds 2, 4, 3 and 1 (each within the scatter of the next).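

In this assay the result is a number 1 percentage points lower from compound 3 to compound 4 (within the scatter) and this is the only step shown that falls on the carbonyl carbon itself, whereas the earlier steps concerned a substituent on the outer ring and the oxygen. At the one concentration tested, 3-(trifluoromethyl)phenyl in place of (3,4-dichlorophenyl)amino thus gives a number that cannot be told apart from that of compound 3, even though the group that leaves carries a hydrogen-bond donor and the group that enters carries none. Nothing measured here explains this result.

All four numbers lie so close together that they leave open whether this position matters at higher concentrations. On these data alone, what a carboxylic acid or an aliphatic amine on this carbonyl carbon would give also remains open.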